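The source may hold more compounds than are shown below. What is called first, only, known or untested is meant among the compounds shown, and "the series" means these compounds.

Measured compounds:
compound 1 `O=C1/C(=C/c2ccccc2F)CN(S(=O)(=O)c2ccc(O[N+](=O)[O-])cc2)C/C1=C\c1ccccc1F`: 6200 nM
compound 2 `O=C1/C(=C/c2ccccc2F)CN(S(=O)(=O)c2ccc(Cl)cc2)C/C1=C\c1ccccc1F`: 4500 nM
compound 3 `Cc1ccc(S(=O)(=O)N2C/C(=C\c3cccc(F)c3)C(=O)/C(=C/c3cccc(F)c3)C2)cc1`: 18100 nM

These values come from a functional assay on SMMC-7721 cells (Homo sapiens) for cytotoxicity, read by MTT assay, with a stated time of 24 h; a higher number here means a weaker inhibitor, a lower number a stronger inhibitor. Compound 3 gives the highest number of the three and is thus the weakest inhibitor among them; its gaps to compound 1 and to compound 2 both lie beyond the scatter. Compound 4 `N#Cc1ccc(S(=O)(=O)N2C/C(=C\c3cccc(F)c3)C(=O)/C(=C/c3cccc(F)c3)C2)cc1` differs from compound 3 by a single change: cyano in place of methyl on an aromatic carbon. Among the compounds with values here, the only measured step that swaps one group for another on an aromatic carbon, a 1.4-fold lower number from compound 1 to compound 2 (0.14 log units; within the scatter), barely moved the number. On that basis the new group is expected to shift the result little, with no clear direction, and a 1.2-fold lower number from compound 3 to compound 4 (0.08 log units; within the scatter) is the expected step. For compound 4 the estimate is therefore 15000 nM, expected to fall between 6000 nM and 40000 nM.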

Compound 4, half-maximal inhibitory concentration: 4500 nM
For compound 4 the middle estimate is 3.3-fold (0.52 log units) above the measured one, and the stated range ends above it.
By their numbers in this assay, from the lowest: compounds 2, 4 and 1 (each within the scatter of the next); then compound 3.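

In this assay, cyano in place of methyl on this aromatic carbon gives a 4.0-fold lower number from compound 3 to compound 4 (0.60 log units; beyond the scatter) and so moves the number beyond the scatter. Within the data shown here, the earlier swap on an aromatic carbon, a 1.4-fold lower number from compound 1 to compound 2 (0.14 log units; within the scatter), stayed within it, so this pair is the first to show that a change here can matter. No measurement shown explains the size of this step. As far as these compounds go, whether an amine or a carboxylic acid on this carbon would act like cyano remains open. So does whether the same swap would give a similar step on the core of compound 1.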